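A few compounds are considered here, and "the series" means these few. Any claim that something is new, unique, unknown or untested is made for them only; others in the source may bear on it.

All four compounds here are tested in a functional assay on T47D cells (Homo sapiens) for cytotoxicity, read by MTT assay, with a stated time of 2 days; a higher number here means a weaker inhibitor, a lower number a stronger inhibitor. Compound 1 `COc1cccc(-c2nc3ccc(C)cc3c(=O)[nH]2)c1` carries a methoxy group on its aromatic substituent. In this assay compound 1 gives > 50000 nM, which is a limit of the assay and not a number. Compound 2 `Cc1ccc2nc(-c3cccc(OC(F)(F)F)c3)[nH]c(=O)c2c1` differs from compound 1 by trifluoromethyl in place of methyl on an oxygen on an aromatic ring. In this assay compound 2 gives > 50000 nM, again a limit rather than a number. The step that the two limits leave unreadable from compound 1 to compound 2 therefore cannot be read. Compound 3 `COc1cccc(-c2nc3cc(C)ccc3c(=O)[nH]2)c1` is built from the same atoms as compound 1 joined differently; the difference between the two cores is not broken down here. In this assay compound 3 gives > 50000 nM, once more a limit. Among the measured compounds shown here, every measured value so far sits at the limit of > 50000 nM in this assay, at which 3 of the 3 values shown sit, so none of the three compounds shows any readable inhibition.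

Compound 4 `Cc1ccc2c(=O)[nH]c(-c3cccc(OC(F)(F)F)c3)nc2c1` has not yet been measured. It differs from compound 3 by trifluoromethyl in place of methyl on an oxygen on an aromatic ring, the same change that leads from compound 1 to compound 2, at the same place. Since compound 3 gives only the limit > 50000 nM, and since the matching step that the two limits leave unreadable from compound 1 to compound 2 left no readable size, there is no sign that the change moves the value. For compound 4 the expected step is therefore a step that the limit leaves unreadable from compound 3 to compound 4. Compound 4 is expected to give about 60000 nM, most likely again only as a limit, with a plausible range from 20000 nM to 200000 nM.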

Compound 4, half-maximal inhibitory concentration: > 50000 nM
Compound 4 gave a limit, no number; the forecaster's own chance of this, stated with the estimate: 85%; the middle value is on the limit's open side.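

Compound 4 gives only a limit of the assay, as compound 3 does, so the step from compound 3 to compound 4 cannot be read. All the compounds stay at the same limit: the limit of > 50000 nM in this assay, at which 4 of the 4 values shown sit.

The compounds shown leave open whether any change to this shared core can give a readable value in this assay, and how large a step from methoxy to trifluoromethoxy would then be.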